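Swapping an amine for a thiazolidinedione on a shared oxazolidinone core

A few compounds are considered here, and "the series" means these few. Any claim that something is new, unique, unknown or untested is made for them only; others in the source may bear on it.

Compound 2 `O=C1O[C@@H](CN2CCC(O)CC2)CN1c1ccc(-n2cc(-c3ccccn3)cn2)c(F)c1`: 1.63
Compound 1 `CN(CCC#N)C[C@H]1CN(c2ccc(-n3cc(-c4ccccn4)cn3)c(F)c2)C(=O)O1`: 1.9

Of the compounds shown here, two sharing one core have been measured in a physicochemical assay for lipophilicity, read by HPLC, measured as octanol-water partition; on this read-out higher numbers stand for higher lipophilicity and lower numbers for lower lipophilicity. Compound 2 gives 1.63, the lowest of the two numbers; its nearest neighbour is compound 1, which gives 1.9. Within the data shown here, the only measured step is a number 0.27 log units lower from compound 1 to compound 2 (within the scatter), so the two values are indistinguishable.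

Compound 3 `O=C1CSC(=O)N1C[C@H]1CN(c2ccc(-n3cc(-c4ccccn4)cn3)c(F)c2)C(=O)O1` is not yet measured. It differs from compound 2 by 2,4-dioxo-1,3-thiazolidin-3-yl in place of 4-hydroxypiperidin-1-yl on a saturated chain carbon bound to a saturated ring carbon. Among the measured compounds shown here, the one measured step exchanged one amine-bearing group for another, whereas here the entering group is an imide ring with no hydrogen-bond donor, so that step offers only a weak guide. Compound 3 is therefore expected to give 2, with a range from 1.4 to 2.6. That estimate means a step of a number 0.37 log units higher from compound 2 to compound 3 (beyond the scatter), expected to be small and possibly within the scatter.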

Compound 3, partition coefficient: 2.18
Beside the measured number, compound 3's estimate is 0.18 log units below it; the range from low to high includes it.
By their numbers in this assay, from the lowest: compounds 2, 1 and 3 (each within the scatter of the next, the first and the last beyond it).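

In this assay, the place on a saturated chain carbon bound to a saturated ring carbon now shows its first step beyond the scatter: 2,4-dioxo-1,3-thiazolidin-3-yl in place of 4-hydroxypiperidin-1-yl gives a number 0.55 log units higher from compound 2 to compound 3 (beyond the scatter) and so separates two groups of equal heavy-atom count. Against (2-cyanoethyl)(methyl)amino the same group gives only a number 0.28 log units higher from compound 1 to compound 3 (within the scatter) and so cannot be told apart from it, which leaves compound 1 unresolved from both of the others. Nothing available explains what in this exchange produces the step.

Ring size, hetero atoms and hydrogen-bond donors all change together in this swap, so the compounds shown cannot assign the step to any one of them. A plain piperidin-1-yl group without its hydroxyl, or a five-membered dione ring with oxygen in place of the ring sulfur, would pull these changes apart.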